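Chalcone-bearing pyrazolopyrimidines: methoxy pattern on the styryl ring

The source may hold more compounds than are shown below. What is called first, only, known or untested is meant among the compounds shown, and "the series" means these compounds.

Compound 1 `COc1ccc(/C=C/C(=O)c2cc(-c3ccc(OC)c(OC)c3)n3nc(-c4ccccc4)cc3n2)cc1` gives 14900 nM in a functional assay on DU-145 cells (Homo sapiens) for antiproliferative activity, read by MTT assay, with a stated time of 24 h; a higher number here means a weaker inhibitor, a lower number a stronger inhibitor. Compound 2 `COc1ccc(-c2cc(/C=C/C(=O)c3ccc(C)cc3)nc3cc(-c4ccccc4)nn23)cc1OC` gives 26800 nM in this assay; the step of a 1.8-fold higher number from compound 1 to compound 2 (0.25 log units; within the scatter) is within the scatter, so the two stand level on these numbers, and compound 1 holds the lowest of the two values without being separable from compound 2. Compound 3 `COc1ccc(-c2cc(C(=O)/C=C/c3cc(OC)c(OC)c(OC)c3)nc3cc(-c4ccccc4)nn23)cc1OC` differs from compound 1 by 3,4,5-trimethoxyphenyl in place of 4-methoxyphenyl on a double-bonded chain carbon bound to a double-bonded chain carbon. For the measured compounds named here, no measured step touches this change: the only step on record, from compound 1 to compound 2, moves the carbonyl end of the chain, not the aryl on the double-bonded chain carbon, and it stays within the scatter anyway. With nothing to lean on, the expected step of a 1.2-fold lower number from compound 1 to compound 3 (0.09 log units; within the scatter) in this assay is none beyond the scatter, in either direction. Compound 3 is therefore estimated at 12000 nM, with a range from 3500 nM to 40000 nM.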

Compound 3, half-maximal inhibitory concentration: 14700 nM
Compound 3: the middle estimate sits 1.2-fold (0.09 log units) below what was measured, and the stated range covers the measured number.
By their numbers in this assay, from the lowest: compounds 3, 1 and 2 (each within the scatter of the next).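

At the double-bonded chain carbon bound to a double-bonded chain carbon, 3,4,5-trimethoxyphenyl in place of 4-methoxyphenyl gives a 1.0-fold lower number from compound 1 to compound 3 (0.01 log units; within the scatter) in this assay as a reading on the aryl end of the chain, which the earlier step on the carbonyl end did not provide. The entering group carries more heavy atoms and hydrogen-bond acceptors on the same kind of aromatic ring, yet compound 1 and compound 3 stand level on these numbers, so adding methoxy groups to this ring gives no separable difference here. No evidence bearing on this result is at hand.

Open, as far as these compounds go, is whether a group of another kind on this aryl ring, such as an amine or a carboxylic acid, would separate from compound 1. Also open, from the compounds shown here alone, is whether a longer chain between the carbonyl and the aryl ring would do so.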